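Naphthalen-2-yl replacing an aryl ether in a piperidine series

The source may report more compounds than this note shows. Statements on the series, on what has been measured and on what is new or still open speak of the compounds shown alone.

Measured compounds:
compound 1, `COc1cc(C(C)=O)ccc1OCCCN1CCC(C(O)(c2ccc(F)c(F)c2)c2ccc(F)c(F)c2)CC1`: 2.51 nM
compound 2, `CCc1ccc(OCCCN2CCC(C(c3ccc(F)cc3)c3ccc(F)cc3)CC2)c(OC)c1`: 2.51 nM

Of the compounds shown here, two share a core and have been measured in a functional assay (aorta) with Oryctolagus cuniculus as the target; a higher number here means weaker binding, a lower number tighter binding. In this assay compound 1 gives 2.51 nM, and compound 2 gives 2.51 nM. Compound 2 therefore stands level with compound 1 at the digits shown, the two values lying within the usual scatter of each other, so no order between them can be read.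

Compound 3, `Fc1ccc(C(c2ccc(F)cc2)C2CCN(CCCOc3ccc4ccccc4c3)CC2)cc1`, has not yet been measured in this assay. It differs from compound 2 in one place: naphthalen-2-yl in place of 4-ethyl-2-methoxyphenyl on an oxygen on a saturated carbon. The part that leaves carries one hydrogen-bond acceptor; the part that enters carries none.

Going by the values given here, nothing measured so far isolates this change, so the size of the step is a guess. A modest weakening beyond the scatter is expected, with the step from compound 2 to compound 3 estimated at a 2.0-fold higher number from compound 2 to compound 3 (0.30 log units; within the scatter). Compound 3 is expected to give about 5 nM, within a range from 1.5 nM to 16 nM.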

Compound 3, dissociation constant: 7.94 nM
Beside the measured number, compound 3's estimate is 1.6-fold (0.20 log units) below it, and the stated range covers the measured number.
By their numbers in this assay, from the lowest: compounds 1 and 2 (each within the scatter of the next); then compound 3.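

In this assay, putting naphthalen-2-yl in place of 4-ethyl-2-methoxyphenyl on this oxygen gives a 3.2-fold higher number from compound 2 to compound 3 (0.50 log units; beyond the scatter), so the number does respond to the group held here, although the step is modest. The two groups have the same number of heavy atoms, so this change is not a matter of adding or removing bulk by atom count: a single substituted aromatic ring carrying one hydrogen-bond acceptor gives way to two fused aromatic rings of carbon only with no acceptor. Those features all change together in one step, and nothing available here shows which of them accounts for the weaker binding.

The compounds shown leave open whether the methoxy group, the ethyl group or the second aromatic ring matters most, a question that a phenyl ring carrying only the methoxy group or only the ethyl group could help to separate. They also leave open how naphthalen-1-yl, or a naphthalen-2-yl ring carrying a methoxy group, would compare with the groups seen so far.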